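The source may report more compounds than this note shows. Statements on the series, on what has been measured and on what is new or still open speak of the compounds shown alone.

Compound 3 `COc1ccc(S(=O)(=O)NCCCNc2nccc(-c3c(-c4cccc(F)c4)nc4sccn34)n2)cc1` gives 5510 nM in a functional assay on A-375 cells (Homo sapiens) for cytotoxicity, read by MTT assay (on this read-out higher numbers stand for weaker inhibition and lower numbers for stronger inhibition), the lowest of the three numbers in hand, although compound 1 `O=S(=O)(NCCCNc1nccc(-c2c(-c3cccc(F)c3)nc3sccn23)n1)c1ccc(Br)cc1` at 7040 nM sits within the usual scatter of it, while compound 2 `O=S(=O)(NCCCNc1nccc(-c2c(-c3cccc(F)c3)nc3sccn23)n1)c1ccc(F)cc1` gives 14500 nM. Compound 4 `O=S(=O)(NCCCNc1nccc(-c2c(-c3cccc(F)c3)nc3sccn23)n1)c1ccc(C(F)(F)F)cc1` differs from compound 3 in one place: trifluoromethyl in place of methoxy on an aromatic carbon. The measured steps that bear on this exchange are a 1.3-fold lower number from compound 1 to compound 3 (0.11 log units; within the scatter) and a 2.6-fold lower number from compound 2 to compound 3 (0.42 log units; beyond the scatter); both change the same group on that ring and move the number little or only modestly. Among the compounds with values here, no measured pair tests a trifluoromethyl group, so the step of a 1.5-fold higher number from compound 3 to compound 4 (0.16 log units; within the scatter) is expected to be small, probably within the scatter, with a slight lean toward a higher number. Compound 4 is therefore estimated at 8000 nM in this assay, in the range 3500 nM to 18000 nM.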

Compound 4, half-maximal inhibitory concentration: 4090 nM
For compound 4 the middle estimate is 2.0-fold (0.29 log units) above the measured one; measured number inside the range.
By their numbers in this assay, from the lowest: compounds 4, 3 and 1 (each within the scatter of the next); then compound 2.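

In this assay, trifluoromethyl at this ring position stays within the usual scatter of methoxy, a 1.3-fold lower number from compound 3 to compound 4 (0.13 log units; within the scatter), and of bromo, a 1.7-fold lower number from compound 1 to compound 4 (0.24 log units; within the scatter). Within the data shown here, only fluoro stands apart, a 3.5-fold lower number from compound 2 to compound 4 (0.55 log units; beyond the scatter), so compound 2 is the one compound separated beyond the scatter from each of the other three. Nothing measured here explains why fluoro differs from the other groups. The compounds shown leave open whether an amine or a carboxylic acid on this aromatic carbon would stay in the same range.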